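This account rests on a few compounds, and the source may have more. Where it says the series, first, only, none or still open, it means among the compounds named here.

For the measured compounds named here, compound 1 `OC[C@H]1O[C@@H](n2cnc3c(NCc4ccccc4)nccc32)C[C@@H]1O` is the one compound here with a number in a functional assay on EL4 cells (Mus musculus) for inhibition, tested at 100 uM; a higher number here means more inhibition at the concentration tested (going by the name of the read-out), a lower number less inhibition: compound 1 gives 8%. Compound 2 `[O-][n+]1ccc2c(c1)ncn2[C@H]1C[C@H](O)[C@@H](CO)O1` reaches only a limit of the assay, < 5%, as the limit of < 5% in this assay, at which 1 of the 2 values shown sits, records. Compound 3 `CSc1nccc2c1ncn2[C@H]1C[C@H](O)[C@@H](CO)O1` is not yet measured; it differs from compound 1 by methylsulfanyl in place of benzylamino on an aromatic carbon. Going by the values given here, no step between measured compounds is available for this assay, so only an expectation can be given: a small step, downward if anything, not beyond the scatter. Compound 3 is expected to give 5%, between 0% and 15%. The expected step is a number 3 percentage points lower from compound 1 to compound 3 (within the scatter).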

Compound 3, a percentage reported as inhibition, at one concentration (the size of the read-out at that concentration, not a potency): < 5%
Compound 3: only a limit was reported; the forecaster's own chance of this, stated with the estimate: 50%; the middle value sits exactly at the limit.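

In this assay, methylsulfanyl in place of benzylamino on this aromatic carbon, next to the ring nitrogen, gives a number at least 3 percentage points lower from compound 1 to compound 3 (that floor lies within the scatter). Exchanging a group that has a six-membered aromatic ring for one with no ring therefore yields no change that can be told from the scatter. The result for compound 3 is a limit and not a number, so the true size of the step cannot be read: the limit of < 5% in this assay, at which 2 of the 3 values shown sit.

On these data alone, it remains open whether an amine, a longer alkyl chain or a carboxylic acid at this position would give a clear inhibition reading in this assay.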